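The source may hold more compounds than are shown below. What is called first, only, known or untested is meant among the compounds shown, and "the series" means these compounds.

Compound 1, `N#Cc1ccc(NC(=O)NCc2cnc3scc(-c4ccc(Br)cc4)n23)cc1`, is the strongest of the two compounds that gave a number in an assay on isolated protein for inhibition of Indoleamine 2,3-dioxygenase 1 (Homo sapiens), with a stated time of 30 min; on this read-out lower numbers stand for stronger inhibition and higher numbers for weaker inhibition: compound 1 gives 77 nM. The nearest measured compound, compound 3 with structure `CCOC(=O)c1cnc2scc(-c3ccc(CC)cc3)n12`, gives 24000 nM, a gap well beyond the usual scatter of this assay. Compound 2, `CCOC(=O)c1cnc2scc(Cc3ccccc3)n12`, did not give a number in this assay at all; compound 2 shows > 100000 nM, which is a limit of the assay rather than a measured value, as the limit of > 100000 nM in this assay, at which 1 of the 3 values shown sits, states. For the measured compounds named here, compound 3 and compound 2 both carry an ethyl ester on the shared core where compound 1 carries the urea chain, so neither offers a step that differs in only one place from compound 1.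

Compound 4, `COc1ccc(NC(=O)NCc2cnc3scc(-c4ccc(Br)cc4)n23)cc1`, keeps the whole of compound 1 except for one change: methoxy in place of cyano on an aromatic carbon. No measured pair among the compounds shown isolates this exchange, so its effect has to be estimated. The exchange is expected to weaken inhibition somewhat, by a step of a 2.6-fold higher number from compound 1 to compound 4 (0.41 log units; beyond the scatter), since the cyano group of compound 1 is replaced by a methoxy group of the same size. Compound 4 is therefore expected to give about 200 nM in this assay, within a range of 60 nM to 700 nM.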

Compound 4, half-maximal inhibitory concentration: 190 nM
For compound 4 the middle estimate is 1.1-fold (0.02 log units) above the measured one; the measured number falls inside the stated range.
By their numbers in this assay, from the lowest: compound 1; then compound 4; then compound 3. At a limit, above all of these: compound 2.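

For the compounds shown here, compound 1 and compound 4 are the first pair here that differs in only one place, so they give the first direct reading of a change on the six-membered aromatic ring of carbon only, para to a large group. In this assay the exchange of cyano for methoxy gives a 2.5-fold higher number from compound 1 to compound 4 (0.39 log units; beyond the scatter) and so costs some inhibition without removing it, with compound 4 still at 190 nM. The two groups match in what can be counted, with 2 heavy atoms and 1 hydrogen-bond acceptor each, and nothing measured here explains the size of this step.

On these data alone, two groups at one position cannot show a trend, so it stays open whether a plain hydrogen, a chlorine, an amine or a carboxylic acid at this place would give a number nearer to compound 1 or to compound 4. As far as these compounds go, it is also open whether the same exchange would give a step of similar size if a chlorine or a methyl group stood in place of the bromine on the other aromatic ring.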